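Reading a Sulfonyl Swap on Compound 2

The source may hold more compounds than are shown below. What is called first, only, known or untested is meant among the compounds shown, and "the series" means these compounds.

Compound 1 `CN1CCN(c2ccc(Nc3ncc4cc(S(=O)(=O)c5ccc(F)cc5F)c(=O)n(C)c4n3)cc2)CC1`: 5000 nM
Compound 2 `Cn1c(=O)c(S(=O)(=O)Cc2ccc(F)cc2F)cc2cnc(Nc3ccc4[nH]ccc4c3)nc21`: 1000 nM
Compound 3 `Cn1c(=O)c(S(=O)(=O)c2ccccc2)cc2cnc(Nc3ccc4cc[nH]c4c3)nc21`: 10000 nM

All three values come from a functional assay on K562 cells (Homo sapiens) for inhibition, read by trypan blue exclusion, with a stated time of 72 h; a lower number here means a stronger inhibitor, a higher number a weaker inhibitor. Compound 2 has the lowest number of the three, and the numbers for the other two lie above it by more than the usual scatter. No two of these compounds differ in just one place, so the data do not isolate the effect of any single change.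

The next compound is compound 4 `Cn1c(=O)c(S(=O)(=O)Nc2ccc(F)cc2)cc2cnc(Nc3ccc4[nH]ccc4c3)nc21`, which differs from compound 2 in one place: (4-fluorophenyl)amino in place of 2,4-difluorobenzyl on a sulfonyl sulfur. In words, this is (4-fluorophenyl)amino in place of 2,4-difluorobenzyl on a sulfonyl sulfur.

Among the measured compounds, only compound 2, at 1000 nM, carries 2,4-difluorobenzyl. The two without it, compound 1 at 5000 nM and compound 3 at 10000 nM, both give higher numbers, although they also differ from compound 2 elsewhere. This is only a loose hint, but it leads to the expectation of a modestly weaker inhibitor, not a stronger one. The expected change is a 2.5-fold higher number from compound 2 to compound 4 (0.40 log units; beyond the scatter). For compound 4 the estimated value is 2500 nM, with an expected range of 600 nM to 10000 nM.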

Compound 4, half-maximal inhibitory concentration: 5000 nM
Beside the measured number, compound 4's estimate is 2.0-fold (0.30 log units) below it; low and high end bracket the measured number.
By their numbers in this assay, from the lowest: compound 2; then compounds 1, 4 and 3 (each within the scatter of the next).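

In this assay, for the compounds shown here, the change gives a 5.0-fold higher number from compound 2 to compound 4 (0.70 log units; beyond the scatter), the first step in which a single place is altered, and it shows that the group on this sulfonyl sulfur matters to the number, since the step lies beyond the scatter. Both groups carry one six-membered aromatic ring of carbon only, so keeping that ring is not enough to hold the number where compound 2 has it. The swap alters several things at once, however: (4-fluorophenyl)amino brings a nitrogen and a hydrogen-bond donor and has one fluorine, whereas 2,4-difluorobenzyl has no donor and two fluorines, and nothing measured here explains the weaker result.

From the compounds shown here alone, what stays open is which of these differences counts. A (2,4-difluorophenyl)amino group would keep both fluorines while carrying the nitrogen, and a 4-fluorobenzyl group would keep the carbon link with a single fluorine, so these two would help pull the fluorine count apart from the nitrogen link.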